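Swapping a difluorophenyl for a furan on the thiazole core

The compounds below may be only part of what the source reports. "The series", "measured", "known", "first", "only" and "open" are said of these compounds alone.

Compound 1, `O=C(O)Cc1sc(C(c2ccccc2)c2ccc(O)cc2)nc1-c1ccc(F)cc1`, gives 3.4 nM in an in vitro assay on HEK385-7 cells for displacement of a labelled ligand from prostaglandin D2 receptor 2 (Homo sapiens); a higher number here means a weaker inhibitor, a lower number a stronger inhibitor.
Compound 2, `O=C(O)Cc1sc(C(c2ccc(F)cc2)c2ccc(F)cc2)nc1-c1cc(F)cc(F)c1`, gives 35 nM in this assay.

Among the two measured compounds, compound 2 has the higher number in this assay; its nearest neighbour, compound 1, shows a number that is lower by an amount beyond the scatter. The two compounds differ in several places at once, so the data show only what their two values are, and nothing about which of the differences matters.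

Compound 3, `O=C(O)Cc1sc(C(c2ccc(F)cc2)c2ccc(F)cc2)nc1-c1ccco1`, has not yet been measured. It differs from compound 2 in one place: furan-2-yl in place of 3,5-difluorophenyl on an aromatic carbon. Among the measured compounds shown here, no measured pair shows what this change does on its own, and the pair of compound 1 and compound 2 does not isolate it either. The account therefore expects compound 3 to sit close to compound 2, with a step from a 1.7-fold higher number from compound 2 to compound 3 (0.23 log units; within the scatter) that may fall within the scatter or reach a modest weakening. The estimate for compound 3 in this assay is 60 nM, expected to lie between 15 nM and 250 nM.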

Compound 3, half-maximal inhibitory concentration: 18 nM
Compound 3: the middle estimate sits 3.3-fold (0.52 log units) above what was measured; the range from low to high includes it.
By their numbers in this assay, from the lowest: compound 1; then compounds 3 and 2 (each within the scatter of the next).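

Among the compounds shown here, this is the first step that isolates a single place, the aromatic carbon next to the ring nitrogen and next to the ring atom that bears the carboxymethyl group. In this assay, replacing 3,5-difluorophenyl with furan-2-yl gives a 1.9-fold lower number from compound 2 to compound 3 (0.29 log units; within the scatter), so the two groups cannot be told apart here, even though the entering group is a five-membered aromatic ring of 5 heavy atoms with 1 hydrogen-bond acceptor and the leaving group a six-membered carbon ring of 8 heavy atoms with no acceptor. Nothing measured explains why this exchange leaves the value within the scatter, and no separate data bear on the result.

For the compounds shown here, since the only two groups compared at this place are both aromatic rings, it remains open whether a non-aromatic group such as an amine or a longer alkyl chain would be accepted there, or whether a thiophen-2-yl would behave like furan-2-yl. Compound 1 differs from compound 2 and compound 3 in several places, so it also remains open which of those differences, such as the hydroxyl group that compound 1 carries, accounts for its value of 3.4 nM.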